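Heteroaryl sulfanyl exchange on a shared core

The source may report more compounds than this note shows. Statements on the series, on what has been measured and on what is new or still open speak of the compounds shown alone.

Measured so far:
compound 1 `C#CCSc1nc(Sc2nc3ccccc3s2)c(C#N)c(-c2cc(OC)c(OC)c(OC)c2)n1` — > 20000 nM
compound 2 `C#CCSc1nc(Sc2nccs2)c(C#N)c(-c2ccc(Cl)cc2)n1` — 3230 nM

Of the compounds shown here, two have been measured in a functional assay on MCF7 cells (Homo sapiens) for antiproliferative activity, read by MTT assay, with a stated time of 72 h; on this read-out lower numbers stand for stronger inhibition and higher numbers for weaker inhibition. Compound 1 gives only a limit of the assay, > 20000 nM, so its position on this read-out is known only as the limit of > 20000 nM in this assay, at which 1 of the 2 values shown sits. Compound 2 differs from compound 1 in several places, and compound 2 gives 3230 nM in this assay. Among the measured compounds shown here, no single step between the two is defined, and the pair shows only that one member reaches a number while the other does not.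

Compound 3 `C#CCSc1nc(Sc2nc(C)cs2)c(C#N)c(-c2cc(OC)c(OC)c(OC)c2)n1` is not yet measured. It differs from compound 1 in one place: 4-methyl-1,3-thiazol-2-yl in place of 1,3-benzothiazol-2-yl on a sulfur. For the measured compounds named here, compound 1 sits at a limit, and no measured step bounds this change. The step from compound 1 to compound 3 is expected to read an at least 1.6-fold lower number from compound 1 to compound 3 (0.22 log units; that floor lies within the scatter), in the direction of stronger inhibition, without a measured anchor to say whether it passes beyond the usual scatter. Compound 3 is estimated at 12000 nM, with a range from 3000 nM to 40000 nM. A limit again remains a real possibility for compound 3.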

Compound 3, half-maximal inhibitory concentration: > 20000 nM
Compound 3: only a limit was reported; the forecaster's own chance of this, stated with the estimate: 40%; middle value at least 1.6-fold (0.22 log units) from the limit.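

No step can be read between compound 1 and compound 3, since each is reported only as a limit of the assay: the limit of > 20000 nM in this assay, at which 2 of the 3 values shown sit.

The compounds shown leave open how far 1,3-benzothiazol-2-yl and 4-methyl-1,3-thiazol-2-yl on a sulfur differ in this assay, and whether either group on the core of compound 1 can give a number rather than a limit.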